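Swapping methyl for chloro on two related thiazole-imine amides

The source may hold more compounds than are shown below. What is called first, only, known or untested is meant among the compounds shown, and "the series" means these compounds.

Of the compounds shown here, three have been measured for how tightly they block the vitamin D3 receptor, and a fourth awaits its number. Compound 1 `CC(=O)N1CCN(C(=O)Cn2c(-c3ccc(C)cc3)csc2=N)CC1` carries a methyl-bearing phenyl ring on a shared core; in an assay on isolated protein for inhibition of vitamin D3 receptor (Homo sapiens) (a lower number here means a stronger inhibitor, a higher number a weaker inhibitor), compound 1 gives 2840 nM. Compound 3 `CC(=O)N1CCN(C(=O)Cn2c(-c3ccc(Cl)cc3)csc2=N)CC1` differs from compound 1 in one place: chloro in place of methyl on an aromatic carbon. That change gives a 1.2-fold lower number from compound 1 to compound 3 (0.10 log units; within the scatter), so in this assay compound 3, at 2280 nM, cannot be told apart from compound 1.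

Compound 2 `Cc1ccc(-c2csc(=N)n2CC(=O)N2CCOCC2)cc1` keeps the methyl-bearing phenyl ring but has a different amide part; how its core differs from that of compound 1 is not broken down here. In this assay compound 2 gives 13700 nM, a weaker inhibitor than compound 1 or compound 3 by a margin that is beyond the scatter.

Compound 4 `N=c1scc(-c2ccc(Cl)cc2)n1CC(=O)N1CCOCC1` is still unmeasured. It stands to compound 2 as compound 3 stands to compound 1: chloro in place of methyl on an aromatic carbon. The place of the change is described in the same words in both pairs, so this is the same change made on a different core. Because a 1.2-fold lower number from compound 1 to compound 3 (0.10 log units; within the scatter), the step is expected to be small, and compound 4 is expected to land at a 1.2-fold lower number from compound 2 to compound 4 (0.10 log units; within the scatter) from compound 2. Among the compounds with values here, compound 4 is therefore estimated at 11000 nM, with a range from 5500 nM to 22000 nM, resting on the single earlier step and on the reading of compound 2.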

Compound 4, inhibition constant: 4130 nM
The estimate for compound 4 lay 2.7-fold (0.43 log units) above the measured number; the measured number lies below the stated range.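

In this assay, the swap from 4-methylphenyl to 4-chlorophenyl gives a 3.3-fold lower number from compound 2 to compound 4 (0.52 log units; beyond the scatter), whereas the same swap on the other core gave a 1.2-fold lower number from compound 1 to compound 3 (0.10 log units; within the scatter). Within the data shown here, the size of this step therefore did not carry over unchanged from one core to the other, and the gap between the two steps is larger than repeated measurements would normally produce: the same change on two cores in this assay, a 1.2-fold lower number (0.10 log units; within the scatter) from compound 1 to compound 3 and a 3.3-fold lower number (0.52 log units; beyond the scatter) from compound 2 to compound 4, 2.7-fold (0.43 log units) apart, beyond the scatter of two such steps With only one pair on each core, this result does not show why the steps differ, and it offers no rule for predicting the size of the step on a further core; it shows only that, in this series, a step measured on one core can be a poor guide to the same step on another.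

The compounds shown leave open whether the gap is specific to chloro and methyl or would also appear with other groups in the same place on the aromatic ring, such as fluoro, methoxy or a carboxylic acid. They also leave open how the step would behave with an amide part different from those in compound 1 and compound 2, such as one carrying an amine or a longer chain.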